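Cytotoxicity in the biaryl amide series: methoxy analogue

The compounds below may be only part of what the source reports. "The series", "measured", "known", "first", "only" and "open" are said of these compounds alone.

The series shares one core carrying a biaryl amide. Compound 1 `CCOC(=O)CCCCCOc1cccc(CN(C(=O)c2ccc(-c3cccc(NC(C)=O)c3)cc2)C(C)C)c1` bears a 3-acetamidophenyl, compound 2 `CCOC(=O)CCCCCOc1cccc(CN(C(=O)c2ccc(-c3ccc4ccccc4c3)cc2)C(C)C)c1` a naphthalen-2-yl and compound 3 `CCOC(=O)CCCCCOc1cccc(CN(C(=O)c2ccc(-c3cccc(Oc4ccccc4)c3)cc2)C(C)C)c1` a 3-phenoxyphenyl. In an ADME assay on HEK293 cells (Homo sapiens) for cytotoxicity, read by CellTiter-Glo and resazurin assay, with a stated time of 72 h (a higher number here means that more compound is needed for the effect, a lower number that less compound is needed), compound 1 reaches only a limit, > 26000 nM. In this assay compound 2 likewise gives only a limit, > 26000 nM. In this assay compound 3 also gives only a limit, > 19600 nM. The steps a step that the two limits leave unreadable from compound 1 to compound 2 and a step that the two limits leave unreadable from compound 1 to compound 3 are therefore not readable. Compound 3 stands at the limit of > 19600 nM in this assay, at which 1 of the 3 values shown sits, while the other two values sit at the limit of > 26000 nM in this assay, at which 2 of the 3 values shown sit.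

Compound 4 `CCOC(=O)CCCCCOc1cccc(CN(C(=O)c2ccc(-c3cccc(OC)c3)cc2)C(C)C)c1` differs from compound 3 by methyl in place of phenyl on an oxygen on an aromatic ring, that is, phenoxy to methoxy. Going by the values given here, no measured step bears on this change in a readable size, as all three values sit at limits. No step beyond the scatter is expected in this assay. The expected step that the limit leaves unreadable from compound 3 to compound 4 is thus none beyond the scatter. The estimate for compound 4 is 26000 nM, with a range from 13000 nM to 60000 nM, and most likely again only a limit will be reported.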

Compound 4, half-maximal effective concentration: > 21000 nM
Compound 4: only a limit was reported; the forecaster's own chance of this, stated with the estimate: 85%; the middle value is on the limit's open side.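

In this assay compound 4 again gives only a limit, so the steps to compound 4 from compound 1, compound 2 and compound 3 cannot be read. The compounds shown leave open whether any change on the biaryl amide shifts the half-maximal effective concentration at all.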